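A few compounds are considered here, and "the series" means these few. Any claim that something is new, unique, unknown or untested is made for them only; others in the source may bear on it.

Compound 1 `COc1ccc(NC(=O)c2cn(-c3ccccc3)nc2-c2ccc(C)cc2)cc1` gives 1620 nM in a functional assay on MCF7 cells (Homo sapiens) for cytotoxicity, read by MTT assay, with a stated time of 48 h; a lower number here means a stronger inhibitor, a higher number a weaker inhibitor. Compound 2 `O=C(Nc1ccccc1)c1cn(-c2ccccc2)nc1-c1ccc(Cl)cc1` gives 2340 nM. Compound 3 `O=C(Nc1ccc(Br)cc1)c1cn(-c2ccccc2)nc1-c1ccc(Cl)cc1` gives 5310 nM.

Compound 3 therefore stands highest of the three numbers in this assay, that is, as the weakest inhibitor among them: compound 2 lies nearer to it, compound 1 furthest from it. Among the measured compounds shown here, the one step that has been measured within this set, from compound 2 to compound 3, is a 2.3-fold higher number from compound 2 to compound 3 (0.36 log units; beyond the scatter), so adding bromo to the anilide ring pushed the number up.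

Compound 4 `COc1ccc(NC(=O)c2cn(-c3ccccc3)nc2-c2ccc(Cl)cc2)cc1` differs from compound 3 in one place: methoxy in place of bromo on an aromatic carbon. For the measured compounds named here, no measured pair shows methoxy against bromo directly. What is known is that the bromo-free compound 2 sits lower than compound 3, and that compound 1, which carries the same methoxy group on its anilide ring but a methyl rather than chloro on the other ring, sits lower still. From this, compound 4 is expected to give a lower number than compound 3, with an estimated step of a 2.7-fold lower number from compound 3 to compound 4 (0.42 log units; beyond the scatter). The estimate for compound 4 in this assay is 2000 nM, with a range from 800 nM to 5000 nM.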

Compound 4, half-maximal inhibitory concentration: 1550 nM
Compound 4: middle estimate off by 1.3-fold (0.11 log units), on the high side; low and high end bracket the measured number.
By their numbers in this assay, from the lowest: compounds 4, 1 and 2 (each within the scatter of the next); then compound 3.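

In this assay, the direct swap of bromo for methoxy on this aromatic carbon, para to a large group, gives a 3.4-fold lower number from compound 3 to compound 4 (0.53 log units; beyond the scatter), so the higher number seen with bromo does not carry over to methoxy. Methoxy in place of hydrogen at the same carbon gives a 1.5-fold lower number from compound 2 to compound 4 (0.18 log units; within the scatter), so among hydrogen, bromo and methoxy here, only bromo stands apart. On the other ring, chloro in place of methyl gives a 1.0-fold lower number from compound 1 to compound 4 (0.02 log units; within the scatter), so that change leaves no readable mark on the number in this pair.

Nothing available here explains why bromo stands apart from the other two groups. The compounds shown leave open how an amine, a hydroxyl or a carboxylic acid at this carbon would compare, and whether any group there can bring the number clearly below that of hydrogen.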